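The source may report more compounds than this note shows. Statements on the series, on what has been measured and on what is new or still open speak of the compounds shown alone.

Compound 2 `Cc1ccc(NC(=S)NC(=O)c2ccc(OCc3cccc(F)c3)cc2)cc1-c1nc2ccccc2[nH]1` carries a 3-fluorophenyl group on a saturated chain carbon bound to an oxygen on an aromatic ring. In a functional assay on SW-620 cells (Homo sapiens) for inhibition, read by MTT assay, with a stated time of 48 h (on this read-out lower numbers stand for stronger inhibition and higher numbers for weaker inhibition), compound 2 reaches only the limit of the measurement, > 100000 nM, so its true value is not known as a number. Compound 1 `Cc1ccc(NC(=S)NC(=O)c2ccc(OCc3ccc(C(F)(F)F)cc3)cc2)cc1-c1nc2ccccc2[nH]1` has 4-(trifluoromethyl)phenyl at the same place, and in this assay compound 1 gives 72400 nM. The step of an at least 1.3-fold higher number from compound 1 to compound 2 (0.14 log units; that floor lies within the scatter) is the only measured one here, and one of the two values sits at the limit of > 100000 nM in this assay, at which 1 of the 2 values shown sits. Compound 3 `Cc1ccc(NC(=S)NC(=O)c2ccc(OCc3ccccc3Cl)cc2)cc1-c1nc2ccccc2[nH]1` differs from compound 2 by 2-chlorophenyl in place of 3-fluorophenyl on a saturated chain carbon bound to an oxygen on an aromatic ring. For the measured compounds named here, no measured step covers a change of this kind, so no shift beyond the scatter is expected in this assay. The step of a number no higher from compound 2 to compound 3 (the limit leaves the size open) is an estimate that keeps the weak inhibition seen in compound 2. Compound 3 is therefore expected to show 100000 nM, between 40000 nM and 300000 nM.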

Compound 3, half-maximal inhibitory concentration: 57100 nM
Beside the measured number, compound 3's estimate is 1.8-fold (0.24 log units) above it; the range from low to high includes it.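

Putting 2-chlorophenyl in place of 3-fluorophenyl on the saturated chain carbon bound to an oxygen on an aromatic ring gives an at least 1.7-fold lower number from compound 2 to compound 3 (0.24 log units; that floor lies within the scatter). Going by these compounds, compound 2 stands at a limit of the measurement rather than at a number, and the true size of this step stays unknown: the limit of > 100000 nM in this assay, at which 1 of the 3 values shown sits. For the compounds shown here, the one step between two real numbers at this place is a 1.3-fold lower number from compound 1 to compound 3 (0.10 log units; within the scatter), so 2-chlorophenyl and 4-(trifluoromethyl)phenyl cannot be told apart here.

The three compounds change the group on the ring and its ring location together, which leaves the effect of each alone unknown. Also open, on these data alone, is how this place would read with a phenyl ring carrying an amine or a carboxylic acid.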